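Working notes: trifluoromethyl change across two matched pairs

The compounds below may be only part of what the source reports. "The series", "measured", "known", "first", "only" and "open" are said of these compounds alone.

Compound 1, `C=C(Br)C(=O)Nc1cccc(/C=C2\SC(=O)N(Cc3ccc(C(F)(F)F)cc3)C2=O)c1`, gives 820 nM in a functional assay on HeLa cells (Homo sapiens) for cytotoxicity, read by cell counting, with a stated time of 4 days; a higher number here means a weaker inhibitor, a lower number a stronger inhibitor.
Compound 3, `C=C(Br)C(=O)Nc1cccc(/C=C2\SC(=O)N(Cc3ccccc3)C2=O)c1`, gives 1400 nM in this assay.
Compound 2, `Nc1cccc(/C=C2\SC(=O)N(Cc3ccccc3)C2=O)c1`, gives > 250000 nM in this assay; this is a limit of the assay, not a number.

Compound 4, `Nc1cccc(/C=C2\SC(=O)N(Cc3ccc(C(F)(F)F)cc3)C2=O)c1`, is not yet measured. Compounds 2 and 3 differ in their cores by hydrogen in place of (1-bromoethenyl)carbonyl on a nitrogen on an aromatic ring, and that change made an at least 170-fold lower number from compound 2 to compound 3 (2.25 log units; beyond the scatter). On the core of compound 3, the change trifluoromethyl in place of hydrogen on an aromatic carbon made a 1.7-fold lower number from compound 3 to compound 1 (0.23 log units; within the scatter). Compound 4 carries the same change on the core of compound 2, (trifluoromethyl in place of hydrogen on an aromatic carbon), at the same place. The step from compound 2 to compound 4 is expected to be a number no higher from compound 2 to compound 4 (the limit leaves the size open), resting on the earlier step of a 1.7-fold lower number from compound 3 to compound 1 (0.23 log units; within the scatter) and on compound 2 sitting at the limit of > 250000 nM in this assay, at which 1 of the 3 values shown sits. Compound 4 is therefore estimated at 250000 nM, most likely reported again only as a limit.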

Compound 4, half-maximal inhibitory concentration: > 250000 nM
Compound 4 ended at the assay's limit (the forecaster's own chance of this, stated with the estimate: 85%); the middle value lies on the limit itself.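

Compounds 2 and 4 both sit at a limit of the assay in this assay, so the step between them cannot be read and gives no size for the trifluoromethyl change on that core. Hydrogen in place of (1-bromoethenyl)carbonyl on the nitrogen makes an at least 300-fold higher number from compound 1 to compound 4 (2.48 log units; beyond the scatter), so that change is large on both cores, with or without trifluoromethyl: the same change on two cores in this assay, an at least 170-fold lower number (2.25 log units; beyond the scatter) from compound 2 to compound 3 and an at least 300-fold lower number (2.48 log units; beyond the scatter) from compound 4 to compound 1; the limit leaves it open whether they differ Carrying the trifluoromethyl change from the core of compound 3 to the core of compound 2 is therefore neither confirmed nor refuted, since the values on the second core are limits: the limit of > 250000 nM in this assay, at which 2 of the 4 values shown sit.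

Open, from the compounds shown here alone, is whether an acetyl or chloroacetyl group on that nitrogen would give a number rather than a limit. Also open, going by these compounds, is how a nitrile or methoxy group in place of trifluoromethyl would read on the core of compound 3.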